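This account rests on a few compounds, and the source may have more. Where it says the series, first, only, none or still open, it means among the compounds named here.

In a functional assay on cells (Cancer cell lines, Homo sapiens) for cytotoxicity, read by sulforhodamine B assay, with a stated time of 48 h (a lower number here means a stronger inhibitor of growth, a higher number a weaker inhibitor of growth), compound 2 `COc1ccc(C2CC(c3ccccc3)=NN2C2=NC(=O)/C(=C3\C(=O)Nc4ccccc43)S2)cc1` gives 2010 nM, the second highest of the three numbers measured. Compound 1 `O=C1N=C(N2N=C(c3ccccc3)CC2c2ccccc2O)S/C1=C1/C(=O)Nc2ccccc21` gives 2070 nM, and the step of a 1.0-fold lower number from compound 1 to compound 2 (0.01 log units; within the scatter) is within the scatter. Compound 3 `COc1ccc(C2CC(c3ccccc3)=NN2C2=NC(=O)/C(=C3\C(=O)Nc4ccc(Br)cc43)S2)cc1` gives 180 nM, reached by the step of an 11-fold lower number from compound 2 to compound 3 (1.05 log units; beyond the scatter).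

Compound 4 `O=C1N=C(N2N=C(c3ccccc3)CC2c2ccc(Cl)cc2)S/C1=C1/C(=O)Nc2ccccc21` differs from compound 2 by chloro in place of methoxy on an aromatic carbon. Going by the values given here, no measured step swaps this exact pair of groups. The step from compound 1 to compound 2 changed the same ring and stayed within the scatter, while the large step to compound 3 sat on a different ring. Compound 4 is therefore expected to change little, with a 1.1-fold lower number from compound 2 to compound 4 (0.02 log units; within the scatter), so the estimate for compound 4 is 1900 nM, between 800 nM and 4500 nM.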

Compound 4, concentration for 50% growth inhibition: 270 nM
Estimate against measurement, compound 4: 7.0-fold (0.85 log units) above, outside the stated range (below it).
By their numbers in this assay, from the lowest: compounds 3 and 4 (each within the scatter of the next); then compounds 2 and 1 (each within the scatter of the next).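

In this assay, chloro in place of methoxy gives a 7.4-fold lower number from compound 2 to compound 4 (0.87 log units; beyond the scatter), and 4-chlorophenyl in place of 2-hydroxyphenyl gives a 7.7-fold lower number from compound 1 to compound 4 (0.88 log units; beyond the scatter). So this phenyl ring, where the step between compounds 1 and 2 stayed within the scatter, does respond to the group it carries. Nothing available explains why chloro differs from the other two groups.

Going by these compounds, whether fluoro, a nitrile or an amine at this place would act like chloro remains open. So does whether chloro here would add to the gain from the bromo of compound 3.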